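The source may report more compounds than this note shows. Statements on the series, on what has been measured and on what is new or still open speak of the compounds shown alone.

Measured so far in an assay on VSM-A10 cells for antagonist activity at Endothelin-1 receptor (Rattus norvegicus); on this read-out lower numbers stand for stronger inhibition and higher numbers for weaker inhibition:
compound 1 `Cc1noc(NS(=O)(=O)c2cccc3c(NC(=O)C(C)C)cccc23)c1C`, 880 nM
compound 2 `Cc1noc(NS(=O)(=O)c2cccc3c(NC(C)C)cccc23)c1C`, 20 nM
compound 3 `CNc1cccc2c(S(=O)(=O)Nc3onc(C)c3C)cccc12`, 130 nM

In this assay compound 3 stands second highest of the three numbers, with compound 2 nearest and compound 1 furthest away. Compound 4 `Cc1noc(NS(=O)(=O)c2cccc3c(NCCCCCc4ccccc4)cccc23)c1C` differs from compound 3 by 4-phenylbutyl in place of hydrogen on a saturated chain carbon bound to a nitrogen on an aromatic ring; cut one bond further out, the change reads methyl to 5-phenylpentyl. The step that bears most directly on it is a 6.5-fold higher number from compound 2 to compound 3 (0.81 log units; beyond the scatter), a modest move in which the larger group on the nitrogen carried the lower number. a 44-fold lower number from compound 1 to compound 2 (1.64 log units; beyond the scatter) and a 6.8-fold lower number from compound 1 to compound 3 (0.83 log units; beyond the scatter) point the same way. A larger group on that nitrogen is therefore expected to lower the number again, by an estimated 3.3-fold lower number from compound 3 to compound 4 (0.51 log units; beyond the scatter). Compound 4 is expected to give 40 nM, within 8 nM to 200 nM.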

Compound 4, half-maximal inhibitory concentration: 3050 nM
Estimate against measurement, compound 4: 76-fold (1.88 log units) below; the measured number lies above the stated range.
By their numbers in this assay, from the lowest: compound 2; then compound 3; then compound 1; then compound 4.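

In this assay a larger group on this nitrogen did not keep lowering the number: 5-phenylpentyl gave a 23-fold higher number from compound 3 to compound 4 (1.37 log units; beyond the scatter) when it replaced methyl and a 150-fold higher number from compound 2 to compound 4 (2.18 log units; beyond the scatter) when it replaced isopropyl. So the fall seen from methyl to isopropyl does not extend to this long chain, which even stands behind isopropylcarbonyl (a 3.5-fold higher number from compound 1 to compound 4 (0.54 log units; beyond the scatter)). No measurement shown here accounts for this reversal. The compounds shown leave open whether the chain length or its phenyl ring goes with the rise, a question that a plain pentyl or a benzyl group on that nitrogen would address.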